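Swapping Dimethylamino for Benzyloxy on a Weak Compound

The compounds below may be only part of what the source reports. "The series", "measured", "known", "first", "only" and "open" are said of these compounds alone.

Within the data shown here, in a functional assay on DU-145 cells (Homo sapiens) for inhibition, read by trypan blue exclusion, with a stated time of 96 h (on this read-out higher numbers stand for weaker inhibition of growth and lower numbers for stronger inhibition of growth), compound 3 `CN(C)c1ccc(/C=C(/SCc2ccc(Cl)cc2Cl)C(=O)c2ccc(Cl)cc2)cc1` gives 50000 nM, the highest of the three numbers so far. Compound 1 `O=C(/C(=C\c1ccc(OCc2ccccc2)cc1)SCc1ccc(Cl)cc1)c1ccc(Cl)cc1` gives 1000 nM and compound 2 `O=C(/C(=C\c1ccc(OCc2ccccc2)cc1)S(=O)(=O)Cc1ccc(Cl)cc1)c1ccc(Cl)cc1` gives 1000 nM, both well below compound 3 and beyond the scatter. The next compound, compound 4 `O=C(/C(=C\c1ccc(OCc2ccccc2)cc1)SCc1ccc(Cl)cc1Cl)c1ccc(Cl)cc1`, replaces dimethylamino with benzyloxy on an aromatic carbon: benzyloxy in place of dimethylamino on an aromatic carbon. Compound 1 and compound 2 both carry benzyloxy, while compound 3 carries dimethylamino. Among the measured compounds shown here, the one measured step, no change at the digits printed from compound 1 to compound 2 (within the scatter), shows that the exchange of sulfanyl for sulfonyl left the number unmoved, so the two benzyloxy compounds give a single level to aim at. For the measured compounds named here, no measured pair isolates the swap itself, and the chlorobenzyl group of compound 4 is not the one found in compound 1 and compound 2, so the expectation stays loose. The expected change is a 42-fold lower number from compound 3 to compound 4 (1.62 log units; beyond the scatter), a large fall in the number, meaning stronger inhibition of growth. For compound 4 the estimated value is 1200 nM, with an expected range from 300 nM to 5000 nM.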

Compound 4, concentration for 50% growth inhibition: 1000 nM
Estimate against measurement, compound 4: 1.2-fold (0.08 log units) above, within the range that was stated.
By their numbers in this assay, from the lowest: compounds 1, 2 and 4 (each within the scatter of the next); then compound 3.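

In this assay, among these compounds, benzyloxy in place of dimethylamino on an aromatic carbon, para to a large group, gives a 50-fold lower number from compound 3 to compound 4 (1.70 log units; beyond the scatter) and so provides the first measured pair to isolate this swap. The 2,4-dichlorobenzyl group that compound 4 shares with compound 3 does not hold the number high: adding chloro gives no change at the digits printed from compound 1 to compound 4 (within the scatter) and the exchange of the whole sulfur-bearing substituent gives no change at the digits printed from compound 2 to compound 4 (within the scatter) with benzyloxy in place. No measurement shown gives a reason for the size of the swap's effect.

The compounds shown leave open whether the step belongs to the ether oxygen or to the added ring, which a methoxy or a benzyl group at this position would help separate. They also leave open how a morpholine or a free amine would read here.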